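The source may report more compounds than this note shows. Statements on the series, on what has been measured and on what is new or still open speak of the compounds shown alone.

Working notes on the series.

Compound 1 `O=C1C2CCCN2C(=O)N1CN1CCN(c2ccccc2)CC1` and compound 2 `COc1ccccc1N1CCN(CN2C(=O)C3CCCN3C2=O)CC1` share one core; compound 3 `O=C1C2CCCCN2C(=O)N1CCCN1CCN(c2ccccc2)CC1` and compound 4 `COc1ccccc1N1CCN(CCCN2C(=O)C3CCCCN3C2=O)CC1` share another, and the difference between the two cores is not broken down here. In an assay on isolated protein for binding affinity to Adrenergic receptor alpha-1 (Rattus norvegicus), read by radioligand binding (a lower number here means a stronger inhibitor, a higher number a weaker inhibitor), compound 1 gives 1000 nM, and compound 2 gives 500 nM. The change between them is methoxy in place of hydrogen on an aromatic carbon and it made a 2.0-fold lower number from compound 1 to compound 2 (0.30 log units; within the scatter). In this assay compound 3 gives 11.4 nM; its number stands furthest from that of compound 1 and nearest to that of compound 2, both gaps beyond the scatter.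

Compound 4 is not yet measured. It differs from compound 3 by methoxy in place of hydrogen on an aromatic carbon, the same change as from compound 1 to compound 2, and it occurs twice among the compounds shown. On the other core that change lay within the scatter, so the expectation for the step in this assay is a 2.3-fold lower number from compound 3 to compound 4 (0.36 log units; beyond the scatter), resting on the value of compound 3, 11.4 nM, and on the small earlier step. Compound 4 is therefore estimated at 5 nM, with a likely range from 1.5 nM to 15 nM.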

Compound 4, inhibition constant: 9.9 nM
Compound 4: middle estimate off by 2.0-fold (0.30 log units), on the low side; low and high end bracket the measured number.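

In this assay the change from hydrogen to methoxy makes a 1.2-fold lower number from compound 3 to compound 4 (0.06 log units; within the scatter) and so stays small on the core of compound 3, as it did on the core of compound 1. The two steps do not differ, and the change carries across the two cores as a step of similar size: the same change on two cores in this assay, a 2.0-fold lower number (0.30 log units; within the scatter) from compound 1 to compound 2 and a 1.2-fold lower number (0.06 log units; within the scatter) from compound 3 to compound 4, 1.7-fold (0.24 log units) apart, within the scatter of two such steps. This shows only that phenyl to 2-methoxyphenyl gives no step beyond the scatter in either of these two pairs; it does not show that the change would stay this small on a third core, and two pairs cannot establish a general rule for the series.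

The compounds shown leave open how the difference between the two cores itself bears on the number, since no pair isolates any part of it. They also leave open whether a group other than methoxy on the aromatic ring, such as chloro or hydroxyl, or a longer chain to the core would give a step beyond the scatter.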